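A few compounds are considered here, and "the series" means these few. Any claim that something is new, unique, unknown or untested is made for them only; others in the source may bear on it.

In an ADME assay on FHC cells (Homo sapiens) for cytotoxicity, read by resazurin assay, with a stated time of 48 h (on this read-out lower numbers stand for higher toxicity in this test and higher numbers for lower toxicity in this test), compound 1 (`COc1ccc(S(=O)(=O)Nc2ccc3oc(-c4ccc(NC(=O)c5cccc(C)c5[N+](=O)[O-])cc4)nc3c2)cc1`) gives > 100000 nM as a limit of the assay, not a number. Compound 2 (`O=S(=O)(Nc1ccc(-c2nc3cc(NS(=O)(=O)c4cccc5ccccc45)ccc3o2)cc1)c1cccc2ccccc12`) gives > 100000 nM as a limit too. Compound 3 (`O=C(Nc1ccc(Sc2nc3ccccc3s2)c(Cl)c1)c1cccc(Br)c1O`) also gives > 100000 nM as a limit. Compound 1 therefore stands with the others, at the limit of > 100000 nM in this assay, at which 3 of the 3 values shown sit, in the data so far. Compound 4 (`COc1ccc(S(=O)(=O)Nc2ccc3oc(-c4ccc(NS(=O)(=O)c5cc(Br)ccc5OC)cc4)nc3c2)cc1`) remains unmeasured. It carries (5-bromo-2-methoxyphenyl)sulfonyl in place of (3-methyl-2-nitrophenyl)carbonyl on a nitrogen on an aromatic ring. Going by the values given here, no measured step is available, so no change beyond the scatter is expected in this assay for this swap. The estimated step is a number no higher from compound 1 to compound 4 (the limit leaves the size open) and amounts to none of note. Compound 4 is expected near 100000 nM within an estimated range of 50000 nM to 200000 nM in this test.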

Compound 4, half-maximal cytotoxic concentration: > 100000 nM
Compound 4 gave a limit, no number; the forecaster's own chance of this, stated with the estimate: 75%; the middle value lies on the limit itself.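

No step can be read from compound 1 to compound 4, since both values are limits and not numbers: the limit of > 100000 nM in this assay, at which 4 of the 4 values shown sit. The compounds shown leave open whether any structural change here would give a measurable value.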